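Cyclopropylsulfonyl on the ring amine: estimate for compound 4

The source may report more compounds than this note shows. Statements on the series, on what has been measured and on what is new or still open speak of the compounds shown alone.

Measured in (a functional assay on A549 cells (Homo sapiens) for antiproliferative activity, read by MTT assay, with a stated time of 72 h; a lower number here means a stronger inhibitor, a higher number a weaker inhibitor):
- compound 1 (`CN1CCN(c2ccc(Nc3ncc4nc(Nc5ccc(F)cc5)n([C@@H]5CCN(C(=O)CO)C5)c4n3)cc2)CC1`) gives ("not determined" (no result reported))
- compound 2 (`CN1CCN(c2ccc(Nc3ncc4nc(Nc5ccc(F)cc5)n([C@H]5CCCN(C(=O)CO)C5)c4n3)cc2)CC1`) gives (830 nM)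
- compound 3 (`CN1CCN(c2ccc(Nc3ncc4nc(Nc5ccccc5)n([C@H]5CCNC5)c4n3)cc2)CC1`) gives ("not determined" (no result reported))

Compound 3 has no single number, and compound 1 is in the same position, so compound 2 supplies the only figure in the series. Compound 4 (`CN1CCN(c2ccc(Nc3ncc4nc(Nc5ccccc5)n([C@H]5CCN(S(=O)(=O)C6CC6)C5)c4n3)cc2)CC1`) is still unmeasured. The change (cyclopropylsulfonyl in place of hydrogen on an amine nitrogen in a ring) places cyclopropylsulfonyl in place of hydrogen on an amine nitrogen in a ring. Without a value for compound 3, the size and direction of this step in this assay cannot be read. The working expectation is a result for compound 4 within the scatter of compound 2 (830 nM). The estimated value for compound 4 is 900 nM (expected range 250 nM to 3500 nM).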

Compound 4, half-maximal inhibitory concentration: 540 nM
Estimate against measurement, compound 4: 1.7-fold (0.22 log units) above, within the range that was stated.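

Within the data shown here, compound 3 has no single number in this assay so no step to compound 4 can be read. The compounds shown leave open what cyclopropylsulfonyl on the ring amine changes. No evidence bears on this result.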